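This account rests on a few compounds, and the source may have more. Where it says the series, first, only, none or still open, it means among the compounds named here.

Measured so far in a functional assay on COLO 205 cells (Homo sapiens) for inhibition, read by sulforhodamine B assay, with a stated time of 48 h; a lower number here means a stronger inhibitor of growth, a higher number a weaker inhibitor of growth:
- Compound 1 `Nc1cc(N)c2nc(-c3ccccc3)c(NCc3ccc(Cl)c(Cl)c3)nc2c1`: 17000 nM
- Compound 2 `COc1ccc(CNc2nc3cc(N)cc(N)c3nc2-c2ccccc2)cc1OC`: 7940 nM
- Compound 3 `Nc1cc(N)c2nc(-c3ccccc3)c(NCc3ccc(F)cc3)nc2c1`: 2510 nM

Compound 3 gives the lowest number of the three; its nearest neighbour is compound 2, and both steps to it, a 3.2-fold lower number from compound 2 to compound 3 (0.50 log units; beyond the scatter) and a 6.8-fold lower number from compound 1 to compound 3 (0.83 log units; beyond the scatter), lie beyond the scatter. Compound 4 `COc1ccc(CNc2nc3cc(N)cc(N)c3nc2-c2ccccc2)cc1` differs from compound 3 in one place: methoxy in place of fluoro on an aromatic carbon. For the measured compounds named here, no measured step changes exactly this group alone. The step that bears most on it is a 3.2-fold lower number from compound 2 to compound 3 (0.50 log units; beyond the scatter), where the 3,4-dimethoxyphenyl compound sat higher than the 4-fluorophenyl compound; the step of a 2.1-fold lower number from compound 1 to compound 2 (0.33 log units; beyond the scatter) shows the dimethoxy compound in turn below the dichloro compound. A single methoxy on the 4-fluorophenyl position is therefore expected to cost a modest amount relative to compound 3, likely less than the full gap to compound 2, but the direction is not secure. For compound 4 the expected step is a 1.7-fold higher number from compound 3 to compound 4 (0.22 log units; within the scatter), and the estimate in this assay is 4200 nM with a range from 1500 nM to 12000 nM.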

Compound 4, concentration for 50% growth inhibition: 15500 nM
For compound 4 the middle estimate is 3.7-fold (0.57 log units) below the measured one, outside the stated range (above it).
By their numbers in this assay, from the lowest: compound 3; then compounds 2, 4 and 1 (each within the scatter of the next, the first and the last beyond it).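

Working notes: in this assay, methoxy in place of fluoro, para to a large group, gives a 6.2-fold higher number from compound 3 to compound 4 (0.79 log units; beyond the scatter), so this position does not tolerate the exchange without loss and the single methoxy does not retain the number of the 4-fluorophenyl compound. The second methoxy of compound 2 has no readable effect: a 2.0-fold higher number from compound 2 to compound 4 (0.29 log units; within the scatter). The 4-methoxyphenyl and 3,4-dichlorophenyl groups cannot be told apart, a 1.1-fold lower number from compound 1 to compound 4 (0.04 log units; within the scatter), which leaves compound 3 alone, beyond the scatter of the other three compounds.

Nothing measured here explains why the fluoro compound stands apart.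
Also open, from the compounds shown here alone, is whether fluoro is specifically required or whether a methyl, a hydroxyl or an amine at this aromatic carbon would give a number closer to that of compound 3.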